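The compounds below may be only part of what the source reports. "The series", "measured", "known", "first", "only" and "open" are said of these compounds alone.

Measured so far:
- compound 1, `Cc1cc(C)cc(Cn2c(SCC(=O)Nc3ccccc3Cl)nc3ccc(Cl)cc32)c1`, gives 141000 nM
- compound 2, `Cc1cc(C)cc(Cn2c(SCC(=O)Nc3ccccc3Br)nc3ccc(Cl)cc32)c1`, gives 174000 nM
- compound 3, `Cc1cc(C)cc(Cn2c(SCC(=O)Nc3ccccc3[N+](=O)[O-])nc3ccccc32)c1`, gives 194000 nM

These three numbers come from an ADME assay on MT4 cells (Homo sapiens) for cytotoxicity; a lower number here means that less compound is tolerated, a higher number that more compound is tolerated. Compound 3 sits within the scatter of both others: its gap to compound 2 and its gap to compound 1 are each too small to count as a real difference, so the three compounds are tolerated about equally well.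

Compound 4, `Cc1cc(C)cc(Cn2c(SCC(=O)Nc3ccccc3[N+](=O)[O-])nc3ccc(Cl)cc32)c1`, differs from compound 3 by chloro in place of hydrogen on an aromatic carbon. Going by the values given here, no measured pair shows exactly this change. Among the compounds with values here, the only measured step, a 1.2-fold higher number from compound 1 to compound 2 (0.09 log units; within the scatter), swaps one halogen for another on a different ring and stays within the scatter, so it gives little guidance beyond suggesting that small halogen changes leave this assay largely unmoved. Compounds 1 and 2 already carry this chloro on their core and give numbers close to that of compound 3.

For compound 4 the expected step is therefore a 1.1-fold lower number from compound 3 to compound 4 (0.06 log units; within the scatter), with no change beyond the scatter. The estimate for compound 4 is 170000 nM, ranging from 90000 nM to 320000 nM.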

Compound 4, half-maximal cytotoxic concentration: 131000 nM
Beside the measured number, compound 4's estimate is 1.3-fold (0.11 log units) above it; the measured number falls inside the stated range.
By their numbers in this assay, from the lowest: compounds 4, 1, 2 and 3 (each within the scatter of the next).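

In this assay chloro in place of hydrogen on an aromatic carbon of the shared core, a position para to a fused ring, can now be read directly. It gives a 1.5-fold lower number from compound 3 to compound 4 (0.17 log units; within the scatter) and so makes no real difference to how much compound is tolerated. With that chloro on the core, nitro in place of bromo gives a 1.3-fold lower number from compound 2 to compound 4 (0.12 log units; within the scatter) and nitro in place of chloro gives a 1.1-fold lower number from compound 1 to compound 4 (0.03 log units; within the scatter) and neither swap counts as a real difference. Still open, from the compounds shown here alone, is whether a different group at the chloro position, such as an amine, a carboxylic acid or a longer chain, would move this number beyond the scatter. Nothing available here explains why these values stay so close together.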